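The source may report more compounds than this note shows. Statements on the series, on what has been measured and on what is new or still open speak of the compounds shown alone.

Of the compounds shown here, two built on a shared core have so far been measured in an ADME assay on the whole organism for cytotoxicity, with Artemia salina as the target, with a stated time of 24 h; a higher number here means that more compound is needed for the effect, a lower number that less compound is needed. Compound 1 `Cc1ccc(/C=C/C(=O)c2ccccc2NC(=O)NS(=O)(=O)c2ccc(C)cc2)cc1` gives 15.3 ug/mL in this assay. Among the compounds with values here, compound 2 `Cc1ccc(S(=O)(=O)NC(=O)Nc2ccccc2C(=O)/C=C/c2ccc(N(C)C)cc2)cc1` gives 38.1 ug/mL in this assay, which is the highest of the two numbers; compound 1 is its nearest neighbour, and the gap between them is the one step known, a 2.5-fold higher number from compound 1 to compound 2 (0.40 log units; beyond the scatter), brought about by dimethylamino in place of methyl on an aromatic carbon.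

Compound 3 `COc1cccc(/C=C/C(=O)c2ccccc2NC(=O)NS(=O)(=O)c2ccc(C)cc2)c1` has not yet been measured. It differs from compound 2 by 3-methoxyphenyl in place of 4-(dimethylamino)phenyl on a double-bonded chain carbon bound to a double-bonded chain carbon. Within the data shown here, the single measured step bears on this change only in part: it shows that bringing in the dimethylamino group went with a higher number, and compound 3 gives that group up again, so a move back toward the number of compound 1 is the natural expectation. The entering 3-methoxyphenyl is not the methylphenyl of compound 1, so the size of the move is uncertain, and a modest step down, a 1.7-fold lower number from compound 2 to compound 3 (0.24 log units; within the scatter), is expected. The value of compound 3 in this assay is therefore estimated at 22 ug/mL, with a range from 10 ug/mL to 45 ug/mL.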

Compound 3, concentration for half-maximal effect: 23.2 ug/mL
Compound 3: middle estimate off by 1.1-fold (0.02 log units), on the low side, within the range that was stated.
By their numbers in this assay, from the lowest: compounds 1, 3 and 2 (each within the scatter of the next, the first and the last beyond it).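

In this assay, 3-methoxyphenyl in place of 4-(dimethylamino)phenyl on a double-bonded chain carbon bound to a double-bonded chain carbon gives a 1.6-fold lower number from compound 2 to compound 3 (0.22 log units; within the scatter), and the same group in place of 4-methylphenyl gives a 1.5-fold higher number from compound 1 to compound 3 (0.18 log units; within the scatter). Compound 3 thus cannot be told apart from either of the other two compounds, even though those two differ from each other beyond the scatter, so this position accepts a group with oxygen rather than nitrogen or a plain methyl on the ring, with no clear shift in the number. No measured property of these groups is at hand to account for these numbers.

As far as these compounds go, whether a carboxylic acid or a primary amine on this phenyl ring, or a longer alkoxy chain in place of the methoxy group, would carry the number beyond the scatter remains open. From the compounds shown here alone, all three compounds also share the rest of the core, so it is equally open whether these steps would keep their size if another part of that core were changed.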